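Fluorine on the cyclopropyl ring and cytotoxicity

This account rests on a few compounds, and the source may have more. Where it says the series, first, only, none or still open, it means among the compounds named here.

Three compounds sharing one macrocyclic core have been examined in an ADME assay on cells (Homo sapiens) for activation; on this read-out higher numbers stand for lower toxicity in this test and lower numbers for higher toxicity in this test. Compound 1 `COc1ccc2c(OCC[C@@H]3NC(=O)N(C)CCCC/C=C\[C@@H]4C[C@@]4(C(=O)NS(=O)(=O)C4(C)CC4)NC3=O)cc(-n3ccc(C(C)C)n3)nc2c1Cl` gives 31000 nM in this assay. Compound 2 `COc1ccc2c(OCC[C@@H]3NC(=O)N(C)CCCC/C=C\[C@@H]4C[C@@]4(C(=O)NS(=O)(=O)C4CC4)NC3=O)cc(-c3nc(C(C)C)cs3)nc2c1Cl` gives 40400 nM in this assay. Compound 3 `COc1ccc2c(OCC[C@@H]3NC(=O)N(C)CCCC/C=C\[C@@H]4C[C@@]4(C(=O)NS(=O)(=O)C4(C)CC4)NC3=O)cc(-c3nc(C(C)C)cs3)nc2c1Br` gives 28300 nM in this assay. The gaps from compound 2 to compound 1 and from compound 2 to compound 3 both lie within the usual scatter of this assay, so the three compounds cannot be told apart on these numbers, and compound 2 stands together with the other two rather than apart from them.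

Compound 4 `COc1ccc2c(OCC[C@@H]3NC(=O)N(C)CCCC/C=C\[C@@H]4C[C@@]4(C(=O)NS(=O)(=O)C4(F)CC4)NC3=O)cc(-c3nc(C(C)C)cs3)nc2c1Cl` has not yet been measured in this assay. It differs from compound 2 in one place: fluoro in place of hydrogen on a saturated ring carbon. For the measured compounds named here, no measured pair shows the effect of this change, so the step is expected to be small, with no direction beyond the scatter. The estimated step from compound 2 to compound 4 in this assay is a 1.1-fold lower number from compound 2 to compound 4 (0.03 log units; within the scatter). Compound 4 is therefore expected to give about 38000 nM in this assay, with a likely range from 20000 nM to 72000 nM.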

Compound 4, half-maximal cytotoxic concentration: 51400 nM
For compound 4 the middle estimate is 1.4-fold (0.13 log units) below the measured one; low and high end bracket the measured number.
By their numbers in this assay, from the lowest: compounds 3, 1, 2 and 4 (each within the scatter of the next).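

For the compounds shown here, compound 2 and compound 4 form the first pair here that differs in one place, so the change from cyclopropyl to 1-fluorocyclopropyl can now be read directly in this assay (a 1.3-fold higher number from compound 2 to compound 4 (0.10 log units; within the scatter)). That step lies within the scatter, so this single pair gives no sign that this change separates compound 4 from compound 2 on this read-out. Nothing available explains why the two compounds cannot be told apart.

As far as these compounds go, the step rests on one pair, so it remains open whether it would hold with the other substituents carried by compound 1 and compound 3. From the compounds shown here alone, it also remains open whether a trifluoromethyl group, an amine or a longer chain on the same ring carbon would stay within the scatter.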